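Chloro to trifluoromethyl, a repeated step in the series

This account rests on a few compounds, and the source may have more. Where it says the series, first, only, none or still open, it means among the compounds named here.

Compound 1 `COc1ccccc1-n1c(SCC(=O)Nc2nc3ccc(C(F)(F)F)cc3s2)nc2c(c1=O)SCC2`, compound 3 `COc1ccccc1-n1c(SCC(=O)Nc2nc3ccc(Cl)cc3s2)nc2c(c1=O)SCC2` and compound 2 `O=C(CNC(=O)c1nn(-c2ccccc2)c(=O)c2ccccc12)Nc1nc2ccc(Cl)cc2s1` have been measured in an assay on L cells for inhibition of Protein-serine O-palmitoleoyltransferase porcupine (Mus musculus), read by reporter gene assay, with a stated time of 24 h; a higher number here means that more compound is needed for the effect, a lower number that less compound is needed; compound 4 `O=C(CNC(=O)c1nn(-c2ccccc2)c(=O)c2ccccc12)Nc1nc2ccc(C(F)(F)F)cc2s1` has not. In this assay compound 1 gives 30 nM, compound 3 gives 50 nM and compound 2 gives 30 nM. Compound 1 and compound 3 share one core, compound 2 and compound 4 another; the difference between the two cores is not broken down here. Compound 3 and compound 1 differ by trifluoromethyl in place of chloro on an aromatic carbon, and that step gave a 1.7-fold lower number from compound 3 to compound 1 (0.22 log units; within the scatter). Compound 2 and compound 4 differ by trifluoromethyl in place of chloro on an aromatic carbon, the same change at the same place. The step is expected to be a 1.5-fold lower number from compound 2 to compound 4 (0.18 log units; within the scatter), resting on a 1.7-fold lower number from compound 3 to compound 1 (0.22 log units; within the scatter). For compound 4 the estimate in this assay is 20 nM, between 9 nM and 45 nM.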

Compound 4, half-maximal effective concentration: 110 nM
Compound 4: the middle estimate sits 5.5-fold (0.74 log units) below what was measured, and the stated range ends below it.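

On the core of compound 2, trifluoromethyl in place of chloro gave a 3.7-fold higher number from compound 2 to compound 4 (0.56 log units; beyond the scatter). In this assay the step therefore did not carry from one core to the other: the same change on two cores in this assay, a 1.7-fold lower number (0.22 log units; within the scatter) from compound 3 to compound 1 and a 3.7-fold higher number (0.56 log units; beyond the scatter) from compound 2 to compound 4, 6.1-fold (0.79 log units) apart, beyond the scatter of two such steps. With one pair on each core, this shows that the step cannot be assumed to transfer within these four compounds, but it does not show which part of either core matters or how the step would run on a further core.

Still open, as far as these compounds go, is whether a fluoro, a methyl or a nitrile on the same aromatic carbon would follow chloro or trifluoromethyl on each core. A second pair on each core would show whether this difference between the cores holds.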